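Thiocarbonyl carbamate analogue of the furanoyl thiourea

The source may hold more compounds than are shown below. What is called first, only, known or untested is meant among the compounds shown, and "the series" means these compounds.

Within the data shown here, compound 3 `O=C(NC(=S)N1CCc2c(OCCCCCOc3ccc(Cl)cc3)cccc21)c1ccco1` is the only member of the series with a number rather than a limit in an ADME assay on Huh-7 cells (Homo sapiens) for cytotoxicity (on this read-out higher numbers stand for lower toxicity in this test and lower numbers for higher toxicity in this test), where compound 3 gives 4620 nM. Compound 1 `O=C(NC(=S)N1CCc2c(OCCCCCOc3ccc(Cl)cc3)cccc21)Oc1ccccc1` sits at the limit of this assay, giving > 50000 nM. Compound 2 `Cc1ccc(C(=O)NC(=S)N2CCc3c(OCCCCCOc4ccc(Cl)cc4)cccc32)cc1` likewise reaches only the limit, giving > 50000 nM. The step that the two limits leave unreadable from compound 1 to compound 2 therefore cannot be read. The steps of an at least 10-fold lower number from compound 1 to compound 3 (1.03 log units; beyond the scatter) and an at least 10-fold lower number from compound 2 to compound 3 (1.03 log units; beyond the scatter) both show that the furan-2-yl group on the carbonyl carbon goes with a markedly lower number than either phenoxy or 4-methylphenyl, consistent with the limit of > 50000 nM in this assay, at which 2 of the 3 values shown sit.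

Compound 4 `S=C(NC(=S)N1CCc2c(OCCCCCOc3ccc(Cl)cc3)cccc21)Oc1ccccc1` differs from compound 3 by a group of 9 heavy atoms (7 carbon, 1 oxygen, 1 sulfur; one six-membered aromatic ring of carbon only) in place of a group of 7 heavy atoms (5 carbon, 2 oxygen; one five-membered aromatic ring with 1 hetero atom), on an amide-type nitrogen. Among the measured compounds shown here, this change removes the furan-2-yl carbonyl that, in the step from compound 1 to compound 3, accompanied the drop into measurable numbers, and brings in a phenoxy-bearing group that resembles the one present in compound 1. The reverse of an at least 10-fold lower number from compound 1 to compound 3 (1.03 log units; beyond the scatter) is thus the nearest guide, and a large rise in this assay is expected for compound 4, as a 6.5-fold higher number from compound 3 to compound 4 (0.81 log units; beyond the scatter).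

Compound 4 is estimated at 30000 nM in this assay, with a range from 8000 nM to 100000 nM, and a fair chance that only a limit is reported.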

Compound 4, half-maximal cytotoxic concentration: > 50000 nM
Compound 4: only a limit was reported; the forecaster's own chance of this, stated with the estimate: 50%; middle value at least 1.6-fold (0.22 log units) from the limit.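

this assay records an at least 10-fold higher number from compound 3 to compound 4 (1.03 log units; beyond the scatter) when the group with a six-membered aromatic ring of carbon only and a sulfur replaces (furan-2-yl)carbonyl on the amide-type nitrogen whose other neighbour is the thiocarbonyl carbon. Compound 4 gives > 50000 nM, which is a limit of the assay and not a number. Compound 4 thus joins compound 1 and compound 2, so three different groups at this position reach the limit, compound 3 alone has a number, and the steps among compound 1, compound 2 and compound 4 cannot be read: the limit of > 50000 nM in this assay, at which 3 of the 4 values shown sit.

Still open, from the compounds shown here alone, is whether the lower number of compound 3 would persist with a (thiophen-2-yl)carbonyl group or a (furan-2-yl)thiocarbonyl group on this nitrogen, which would help separate the part played by the furan ring from that of the carbonyl. Also open, going by these compounds, is how far compound 1, compound 2 and compound 4 lie from one another, and whether a group carrying an amine or a carboxylic acid at this position would give a number rather than a limit.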